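The compounds below may be only part of what the source reports. "The series", "measured", "known", "first", "only" and "open" are said of these compounds alone.

Measured in a functional assay on HEK293 cells for agonist activity at Bombesin receptor subtype-3 (Homo sapiens), read by luminescence and calcium flux, with a stated time of 10 min; a higher number here means that more compound is needed for the effect, a lower number that less compound is needed:
compound 1 `CCC(C)(C)Cc1c[nH]c(CCc2ccc(-n3ccnn3)cc2)n1` gives 93 nM
compound 2 `CCC(C)(C)Cc1c[nH]c(CCc2ccc(-c3cnccn3)cc2)n1` gives 100 nM
compound 3 `CCC(C)(C)Cc1c[nH]c(CCc2ccc(-c3cccc(N)n3)cc2)n1` gives 97 nM

Compound 3 stands second highest of these three numbers, yet all three sit within the scatter of one another. Compound 4 `CCC(C)(C)Cc1c[nH]c(CCc2ccc(-c3cccnc3)cc2)n1` is not yet measured; it differs from compound 3 in one place: pyridin-3-yl in place of 6-aminopyridin-2-yl on an aromatic carbon. Every measured step swaps a ring at this same position, and none moved beyond the scatter: a 1.1-fold higher number from compound 1 to compound 2 (0.03 log units; within the scatter), a 1.0-fold higher number from compound 1 to compound 3 (0.02 log units; within the scatter), a 1.0-fold lower number from compound 2 to compound 3 (0.01 log units; within the scatter). A further swap at this position is therefore expected to give no step beyond the scatter, so the expected change is a 1.0-fold higher number from compound 3 to compound 4 (0.01 log units; within the scatter). The estimate for compound 4 in this assay is 100 nM, with a range from 45 nM to 220 nM.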

Compound 4, half-maximal effective concentration: 98 nM
Compound 4: the middle estimate sits 1.0-fold (0.01 log units) above what was measured, and the stated range covers the measured number.
By their numbers in this assay, from the lowest: compounds 1, 3, 4 and 2 (each within the scatter of the next).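

Replacing 6-aminopyridin-2-yl with pyridin-3-yl on this aromatic carbon removes the only hydrogen-bond donor in the group, yet this assay shows a 1.0-fold higher number from compound 3 to compound 4 (0.00 log units; within the scatter). The other new steps agree, with a 1.0-fold lower number from compound 2 to compound 4 (0.01 log units; within the scatter) and a 1.1-fold higher number from compound 1 to compound 4 (0.02 log units; within the scatter), so the four rings at this position cannot be told apart in this assay. Nothing available explains this insensitivity. The compounds shown leave open what a group other than these nitrogen-containing rings would do here, such as a carboxylic acid, a longer chain or a plain phenyl ring.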